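The compounds below may be only part of what the source reports. "The series", "measured", "known", "first", "only" and "open" are said of these compounds alone.

In an ADME assay on NIH3T3 cells (Mus musculus) for cytotoxicity (on this read-out higher numbers stand for lower toxicity in this test and lower numbers for higher toxicity in this test), compound 1 `CC(C)(C)CC#Cc1cc2ncnc(Nc3ccc(OCc4cccc(F)c4)c(Cl)c3)c2s1` gives > 50 uM, which is a limit of the assay. Compound 2 `CC(C)(C)CC#Cc1cc2c(Nc3ccc(OCc4cccc(F)c4)c(Cl)c3)ncnc2s1` gives > 50 uM, also a limit. Compound 2 thus stands at the limit of > 50 uM in this assay, at which 2 of the 2 values shown sit. Compound 3 `COCC#Cc1cc2c(Nc3ccc(OCc4cccc(F)c4)c(Cl)c3)ncnc2s1` differs from compound 2 by methoxy in place of tert-butyl on a saturated chain carbon bound to a triple-bonded carbon. For the measured compounds named here, no measured step shows what such a change does in this assay, so no shift beyond the scatter is expected. The estimated step is a number no higher from compound 2 to compound 3 (the limit leaves the size open). For compound 3 the estimate is 50 uM, with the result expected between 25 uM and 100 uM.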

Compound 3, half-maximal toxic concentration: 1.7 uM
Compound 3: the middle estimate sits 29-fold (1.47 log units) above what was measured, outside the stated range (below it).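

In this assay, the group on a saturated chain carbon bound to a triple-bonded carbon matters: methoxy in place of tert-butyl gives an at least 29-fold lower number from compound 2 to compound 3 (1.46 log units; beyond the scatter). The lower number stands for higher toxicity in this test. The full size of the step stays open because compound 2 sits at a limit of the assay: the limit of > 50 uM in this assay, at which 2 of the 3 values shown sit.

The compounds shown leave open whether the oxygen of methoxy or the loss of the tert-butyl carbons carries this step. They also leave open whether an amine or a longer ether chain here would read like methoxy or like tert-butyl.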